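Ring Size Beside the Acrylamide and Solubility

A few compounds are considered here, and "the series" means these few. Any claim that something is new, unique, unknown or untested is made for them only; others in the source may bear on it.

compound 1, `C=CC(=O)N1CC[C@H](N2C(=O)N(c3ccccc3)Cc3cnc(Nc4cccc(N5CCN(C)CC5)c4)nc32)C1`: 714 ug/mL in a physicochemical assay for solubility, read by HPLC, in phosphate buffer, measured as thermodynamic solubility, with a stated time of 24 h, at pH 6.8; on this read-out lower numbers stand for lower solubility and higher numbers for higher solubility
compound 2, `C=CC(=O)N1CC[C@H](N2C(=O)N(c3ccccc3)Cc3cnc(Nc4ccc(N5CCN(C)CC5)c(OC)c4)nc32)C1`: 256 ug/mL in this assay
compound 3, `C=CC(=O)N1CCC[C@@H](N2C(=O)N(Cc3ccccc3)Cc3cnc(Nc4ccc(N5CCN(C)CC5)cc4OC)nc32)C1`: 142 ug/mL in this assay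

Compound 3 holds the lowest of the three numbers; its gap to compound 2 lies within the scatter of repeated measurements, whereas compound 1 stands clearly beyond it. Compound 4 `C=CC(=O)N1CC[C@@H](N2C(=O)N(Cc3ccccc3)Cc3cnc(Nc4ccc(N5CCN(C)CC5)cc4OC)nc32)C1` differs from compound 3 in a single place: 1-(vinylcarbonyl)pyrrolidin-3-yl in place of 1-(vinylcarbonyl)piperidin-3-yl on an amide-type nitrogen in a ring. Going by the values given here, no measured pair shows this exact change, so its direction cannot be read from the data; the ring shrinks by one carbon and nothing else moves. Compound 4 is therefore expected to stay close to compound 3, with an estimated step of a 1.3-fold higher number from compound 3 to compound 4 (0.10 log units; within the scatter) that remains within the scatter. Compound 4 is expected to give 180 ug/mL in this assay, between 80 ug/mL and 400 ug/mL.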

Compound 4, solubility: 199 ug/mL
For compound 4 the middle estimate is 1.1-fold (0.04 log units) below the measured one, and the stated range covers the measured number.
By their numbers in this assay, from the lowest: compounds 3, 4 and 2 (each within the scatter of the next); then compound 1.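

Going by these compounds alone, the pair compound 3 and compound 4 gives the first reading at this position: in this assay, 1-(vinylcarbonyl)pyrrolidin-3-yl in place of 1-(vinylcarbonyl)piperidin-3-yl on the amide-type nitrogen gives a 1.4-fold higher number from compound 3 to compound 4 (0.15 log units; within the scatter). Going from the six-membered to the five-membered ring, with the benzyl group kept, therefore leaves the number within the scatter. Nothing at hand offers an explanation for this result. Still open, going by these compounds, is how a smaller ring, such as 1-(vinylcarbonyl)azetidin-3-yl, or an open acryloylaminoethyl chain would read at this place. The compounds shown also leave open whether the ring change would read the same with a phenyl group in place of the benzyl group.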